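Imidazolyl for Dimethylcarbamoyl: a Single Swap on Compound 3

The source may hold more compounds than are shown below. What is called first, only, known or untested is meant among the compounds shown, and "the series" means these compounds.

Compound 1, `N=C(N)c1ccc(Oc2nc(Oc3ccc(C(=N)N)cc3)c(Cl)cc2Cl)cc1`: 2700 nM
Compound 2, `N=C(N)c1cccc(Oc2nc(Oc3cccc(C(=N)N)c3)c(Cl)cc2Cl)c1`: 2100 nM
Compound 3, `CN(C)C(=O)c1cccc(Oc2cc(C(=O)O)cc(Oc3cc(C(=N)N)ccc3O)n2)c1`: 300 nM

Of the compounds shown here, three have been tested in an assay on isolated protein for inhibition of serine protease 1 (Bos taurus); on this read-out higher numbers stand for weaker inhibition and lower numbers for stronger inhibition. Compound 3 gives the lowest number of the three, and its gap to compound 2 and to compound 1 lies beyond the usual scatter, so among these three it is the strongest inhibitor. Compound 1 and compound 2 give numbers close to each other.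

Compound 4, `N=C(N)c1ccc(O)c(Oc2cc(C(=O)O)cc(Oc3cccc(-n4ccnc4)c3)n2)c1`, is not yet measured. It differs from compound 3 in one place: 1H-imidazol-1-yl in place of dimethylcarbamoyl on an aromatic carbon. The rest of the molecule, including the acid on the shared core and the amidine-bearing phenol, stays the same.

Among the measured compounds shown here, no measured pair here shows what such a swap does in this assay, so the expectation rests on compound 3 alone. A change of this kind is expected to shift the number only a little, within or near the scatter, with a slight lean toward stronger inhibition. The step from compound 3 to compound 4 is therefore estimated at a 1.5-fold lower number from compound 3 to compound 4 (0.18 log units; within the scatter). For compound 4 the expected value in this assay is 200 nM, within a range from 50 nM to 800 nM.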

Compound 4, inhibition constant: 1200 nM
The estimate for compound 4 lay 6.0-fold (0.78 log units) below the measured number; measured number above the stated range.
By their numbers in this assay, from the lowest: compound 3; then compounds 4, 2 and 1 (each within the scatter of the next, the first and the last beyond it).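

In this assay, putting 1H-imidazol-1-yl in place of dimethylcarbamoyl brings a 4.0-fold higher number from compound 3 to compound 4 (0.60 log units; beyond the scatter) and so weakens inhibition. Among the compounds shown here, this is the first sign that this place on the six-membered aromatic ring is not indifferent to the group it carries. The two groups have the same count of heavy atoms and neither has a net charge, so matching those counts does not keep the number unchanged. Nothing measured here gives a reason for the weaker inhibition.

As far as these compounds go, whether a primary amide, a simple amine or a pyridine ring at this place would hold the number of compound 3 remains open. Also open, from the compounds shown here alone, is whether the same swap would have a similar effect on a different core.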